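Aryl substituent swaps on the piperazine-linked series

The compounds below may be only part of what the source reports. "The series", "measured", "known", "first", "only" and "open" are said of these compounds alone.

Compound 3 `CSc1ccccc1N1CCN(CCCNc2ncccc2C(=O)N(C)C)CC1` stands nearest to compound 1 `CN(C)C(=O)c1cccnc1NCCCN1CCN(c2ccccc2O)CC1` and furthest from compound 2 `CN(C)C(=O)c1cccnc1NCCCN1CCN(c2ccccc2OCC2CC2)CC1`: in a functional assay on aorta for antagonist activity at Alpha-1D adrenergic receptor (Rattus norvegicus) (on this read-out lower numbers stand for tighter binding and higher numbers for weaker binding), compound 3 gives 31.6 nM, compound 1 gives 63.1 nM and compound 2 gives 10 nM. Compound 4 `CCCc1ccccc1N1CCN(CCCNc2ncccc2C(=O)N(C)C)CC1` alters the same aromatic carbon: propyl in place of methylsulfanyl on an aromatic carbon. Within the data shown here, the steps that bear on it are a 2.0-fold lower number from compound 1 to compound 3 (0.30 log units; within the scatter) and a 3.2-fold higher number from compound 2 to compound 3 (0.50 log units; beyond the scatter), with a 6.3-fold lower number from compound 1 to compound 2 (0.80 log units; beyond the scatter) spanning the whole range seen at this position. Among the measured compounds shown here, no measured step covers propyl itself, so only a modest step, if any, is expected, as a 1.6-fold lower number from compound 3 to compound 4 (0.20 log units; within the scatter). The number for compound 4 is estimated at 20 nM, with a range from 6 nM to 63 nM.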

Compound 4, dissociation constant: 31.6 nM
For compound 4 the middle estimate is 1.6-fold (0.20 log units) below the measured one; measured number inside the range.
By their numbers in this assay, from the lowest: compound 2; then compounds 3, 4 and 1 (each within the scatter of the next).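

The sulfur and the hydrogen-bond acceptor of methylsulfanyl leave with this swap, yet the read-out holds (no change at the digits printed from compound 3 to compound 4 (within the scatter)), so an all-carbon propyl group is tolerated at this aromatic carbon. Propyl also stays apart from cyclopropylmethoxy (a 3.2-fold higher number from compound 2 to compound 4 (0.50 log units; beyond the scatter)) but not from hydroxy (a 2.0-fold lower number from compound 1 to compound 4 (0.30 log units; within the scatter)), which leaves compound 2 alone at the low end of these four. No evidence on the cause of these steps is at hand.

As far as these compounds go, whether the ring or the oxygen of cyclopropylmethoxy carries its step stays open, as a cyclopropylmethyl group on the aromatic carbon would test. Equally open, from the compounds shown here alone, is how an amine or a carboxylic acid would read at this place.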